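Removing the nitro group from compound 1

This account rests on a few compounds, and the source may have more. Where it says the series, first, only, none or still open, it means among the compounds named here.

Compound 1 `C/N=C(/S)C1=CC(C)(C)Oc2ccc([N+](=O)[O-])cc21` has the lowest number of the two compounds measured in a functional assay (aorta) with Rattus norvegicus as the target; on this read-out higher numbers stand for an effect only at larger amounts of compound and lower numbers for an effect already at smaller amounts: in this assay compound 1 gives 1.29 nM. Its nearest neighbour is compound 2 `C/N=C(/S)C1=CC(C)(C)Oc2ccc(S(C)(=O)=O)cc21`, which in this assay gives 490 nM; the change of methylsulfonyl in place of nitro on an aromatic carbon brings a 380-fold higher number from compound 1 to compound 2 (2.58 log units; beyond the scatter). Compound 3 `C/N=C(/S)C1=CC(C)(C)Oc2ccccc21` is not yet measured. Compared with compound 1 it differs as follows: hydrogen in place of nitro on an aromatic carbon. Within the data shown here, the only measured step that bears on this change is the one at the same position, from compound 1 to compound 2, which was large and went toward a higher number. For compound 3 a step toward a higher number is therefore expected as well, beyond the scatter, though not necessarily of the same size; the estimated step is a 120-fold higher number from compound 1 to compound 3 (2.07 log units; beyond the scatter). Compound 3 is expected to give about 150 nM in this assay, with a range from 15 nM to 1500 nM.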

Compound 3, half-maximal effective concentration: 4470 nM
Estimate against measurement, compound 3: 30-fold (1.47 log units) below; measured number outside the range, above it.
By their numbers in this assay, from the lowest: compound 1; then compound 2; then compound 3.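

Hydrogen on this aromatic carbon brings a 3500-fold higher number from compound 1 to compound 3 (3.54 log units; beyond the scatter) in this assay, so the unsubstituted position now serves as a reference for the two groups. The change to hydrogen from methylsulfonyl still brings a 9.1-fold higher number from compound 2 to compound 3 (0.96 log units; beyond the scatter), which means that methylsulfonyl, though far from nitro, also keeps the number lower than hydrogen does: at this position, both groups give lower numbers than hydrogen, and nitro gives much the lower. Nothing measured on these compounds accounts for this order.

Going by these compounds, it remains open whether any group other than nitro can reach the low number of compound 1 at this carbon; a nitrile, a trifluoromethyl group or an amine there would test this. The three compounds also leave open whether the same order holds when the rest of the shared core changes.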